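The source may hold more compounds than are shown below. What is called first, only, known or untested is meant among the compounds shown, and "the series" means these compounds.

Measured so far in a functional assay on HeLa cells (Homo sapiens) for inhibition, read by CCK-8 assay, with a stated time of 48 h; a lower number here means a stronger inhibitor, a higher number a weaker inhibitor:
compound 1 `O=[N+]([O-])c1ccc(NC(=S)NCCNS(=O)(=O)c2ccc(-c3ccccc3OCc3ccccc3)s2)cc1` gives 7100 nM
compound 2 `O=C(NCCNS(=O)(=O)c1ccc(-c2ccccc2OCc2ccccc2)s1)Nc1cc(C(F)(F)F)cc(C(F)(F)F)c1` gives 13500 nM
compound 3 `O=C(NCCNS(=O)(=O)c1ccc(-c2ccccc2O[C@H]2CC[C@@H](O)CC2)s1)Nc1cc(C(F)(F)F)cc(C(F)(F)F)c1` gives 14100 nM

Compound 3 sits within the scatter of compound 2 and of compound 1; the three numbers show no separation that can be read as a difference. For the measured compounds named here, the single step that changes the group on the oxygen on the aromatic ring, a 1.0-fold higher number from compound 2 to compound 3 (0.02 log units; within the scatter), lies within the scatter.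

Compound 4 `O=C(NCCNS(=O)(=O)c1ccc(-c2ccccc2Oc2ccc(O)c(O)c2)s1)Nc1cc(C(F)(F)F)cc(C(F)(F)F)c1` follows the same line: 3,4-dihydroxyphenyl in place of 4-hydroxycyclohexyl on an oxygen on an aromatic ring. Going by the values given here, the one step that bears on it, that from compound 2 to compound 3, moved nothing beyond the scatter, so no step beyond the scatter is expected here either, in either direction: a 1.0-fold lower number from compound 3 to compound 4 (0.00 log units; within the scatter). In this assay compound 4 is therefore estimated at 14000 nM, expected within 6000 nM to 35000 nM.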

Compound 4, half-maximal inhibitory concentration: > 20000 nM
Compound 4: a limit, no number; the forecaster's own chance of this, stated with the estimate: 10%; middle value at least 1.4-fold (0.15 log units) away from the limit.
By their numbers in this assay, from the lowest: compounds 1, 2 and 3 (each within the scatter of the next). At a limit, above all of these: compound 4.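

In this assay, compound 4 gives a limit of the assay, not a number: the limit of > 20000 nM in this assay, at which 1 of the 4 values shown sits.

Placing 3,4-dihydroxyphenyl on this oxygen gives an at least 1.4-fold higher number from compound 3 to compound 4 (0.15 log units; that floor lies within the scatter) and an at least 1.4-fold higher number from compound 2 to compound 4 (0.17 log units; that floor lies within the scatter), so neither floor separates it from the earlier groups. As far as these compounds go, the aromatic ring and its two hydroxyl groups therefore bring no sign of stronger inhibition here, and the true size of both steps stays unknown.

Open, from the compounds shown here alone, is whether an amine or a carboxylic acid on the group at this oxygen, or a longer chain in place of benzyl, would give a lower number.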